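The source may report more compounds than this note shows. Statements on the series, on what has been measured and on what is new or still open speak of the compounds shown alone.

Compound 1 `O=[N+]([O-])c1ccc(N/C(=N\O)c2ccccc2F)c2nonc12` gives 110000 nM in an assay on isolated protein for inhibition of Tryptophan 2,3-dioxygenase (Homo sapiens), read by spectrophotometry, with a stated time of 1 h; a lower number here means a stronger inhibitor, a higher number a weaker inhibitor.
Compound 2 `O=[N+]([O-])c1ccc(N/C(=N\O)c2ccc(Cl)cc2)c2nonc12` gives 40000 nM in this assay.
Compound 3 `O=[N+]([O-])c1ccc(N/C(=N\O)c2ccc(Br)cc2)c2nonc12` gives 50000 nM in this assay.

Among these three, compound 3 has the second highest number. Its nearest neighbour is compound 2: the step of a 1.3-fold higher number from compound 2 to compound 3 (0.10 log units; within the scatter) shows nothing that separates the two. Its furthest is compound 1, and the step of a 2.2-fold lower number from compound 1 to compound 3 (0.34 log units; beyond the scatter) is the only clear difference in this small set, matched by a 2.8-fold lower number from compound 1 to compound 2 (0.44 log units; beyond the scatter).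

Compound 4 `O=[N+]([O-])c1ccc(N/C(=N\O)c2ccc(F)c(Br)c2)c2nonc12` differs from compound 3 in one place: 3-bromo-4-fluorophenyl in place of 4-bromophenyl on a carbon with a double bond to nitrogen. Going by the values given here, no measured step tests this exact change. The closest guide is the exchange of bromo for chloro on the same ring, a 1.3-fold higher number from compound 2 to compound 3 (0.10 log units; within the scatter), which stayed within the scatter, suggesting that small changes on this ring move the number little. A step beyond the scatter in either direction is therefore not expected in this assay.

Compound 4 is expected to give about 50000 nM in this assay, with a range from 20000 nM to 120000 nM. This amounts to an expected step of no change at the digits printed from compound 3 to compound 4 (within the scatter).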

Compound 4, half-maximal inhibitory concentration: 47000 nM
For compound 4 the middle estimate is 1.1-fold (0.03 log units) above the measured one; the measured number falls inside the stated range.
By their numbers in this assay, from the lowest: compounds 2, 4 and 3 (each within the scatter of the next); then compound 1.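

On the carbon with a double bond to nitrogen, 3-bromo-4-fluorophenyl in place of 4-bromophenyl gives a 1.1-fold lower number from compound 3 to compound 4 (0.03 log units; within the scatter) in this assay, so adding fluoro to the bromo-bearing ring leaves no measurable mark here. Compared with 4-chlorophenyl, the new group gives a 1.2-fold higher number from compound 2 to compound 4 (0.07 log units; within the scatter) and again shows no clear separation, whereas compared with 2-fluorophenyl it gives a 2.3-fold lower number from compound 1 to compound 4 (0.37 log units; beyond the scatter) and compound 1 now stands apart from all three others. No measured evidence here explains why compounds 2, 3 and 4 stay together or why compound 1 stands apart.

On these data alone, what an amine, a carboxylic acid or a methoxy group would do on this ring remains open. Also open, as far as these compounds go, is whether compound 1 stands apart through the place of its fluoro or through lacking chloro or bromo, which a 4-fluorophenyl group could help separate.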